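The source may report more compounds than this note shows. Statements on the series, on what has been measured and on what is new or still open speak of the compounds shown alone.

Within the data shown here, compound 1 `CC(C)(C)[C@@H](O)C(=O)N1[C@@H]2C[C@@H]2C[C@H]1C(=O)NCc1cc(Cl)ccc1-n1cnnn1` is one of three compounds measured in an ADME assay on liver for metabolic stability, with Liver microsome (Homo sapiens) as the target, read by LC-MS, using microsomes; on this read-out higher numbers stand for fast clearance and lower numbers for slow clearance. In this assay, among the measured compounds shown here, compound 1 gives 54 mL.min-1.g-1, one of only two numbers reported, and its nearest neighbour is compound 3. Compound 3 `CC(C)(C)[C@@H](O)C(=O)N1[C@H](C(=O)NCc2cc(Cl)ccc2-n2cnnn2)C[C@@H]2C[C@@H]21` gives 75 mL.min-1.g-1 in this assay; the step of a 1.4-fold higher number from compound 1 to compound 3 (0.14 log units; within the scatter) rests on (the fact that compounds 1 and 3 differ only in the configuration as drawn). Compound 2 `CC(C)(C)[C@@H](O)C(=O)N1C[C@@H]2C[C@@H]2[C@H]1C(=O)NCc1cc(Cl)ccc1-n1cnnn1` gives only a limit in this assay, < 15 mL.min-1.g-1. The unmeasured compound 4 `O=C(NCc1cc(Cl)ccc1-n1cnnn1)[C@@H]1C[C@H]2C[C@H]2N1C(=O)[C@H](O)c1ccccc1` differs from compound 1 in a single place: phenyl in place of tert-butyl on a saturated chain carbon bound to a carbonyl carbon and an oxygen on a saturated carbon. For the measured compounds named here, no measured step involves this exchange; the one quantified step concerns configuration alone and stays within the scatter, so it offers no guide to either the size or the direction of the effect of phenyl in place of tert-butyl. The step of a 1.1-fold higher number from compound 1 to compound 4 (0.05 log units; within the scatter) is therefore expected to be modest, with wide uncertainty in both directions. Compound 4 is estimated at 60 mL.min-1.g-1 in this assay, expected to fall between 25 mL.min-1.g-1 and 150 mL.min-1.g-1.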

Compound 4, intrinsic clearance in microsomes: < 15 mL.min-1.g-1
Compound 4: only a limit was reported (the forecaster's own chance of this, stated with the estimate: 12%); at least 4.0-fold (0.60 log units) between middle value and limit.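

In this assay, phenyl in place of tert-butyl on a saturated chain carbon bound to a carbonyl carbon and an oxygen on a saturated carbon gives an at least 3.6-fold lower number from compound 1 to compound 4 (0.55 log units; beyond the scatter). This is the first step shown that lies beyond the scatter, so the group at this place can move the read-out, which the configuration change between compound 1 and compound 3 did not show. The step is only a minimum, as compound 4 is reported as a limit and not as a number: the limit of < 15 mL.min-1.g-1 in this assay, at which 2 of the 4 values shown sit.

The compounds shown leave open whether cyclohexyl or isopropyl at this place would follow phenyl or tert-butyl. They also leave open whether phenyl in place of tert-butyl would give a similar step on the core of compound 2 or in the configuration of compound 3.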